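The source may hold more compounds than are shown below. What is called first, only, known or untested is meant among the compounds shown, and "the series" means these compounds.

Compound 1, `COc1cc(-c2nn(-c3cccc(NC(=O)Nc4ccc(Cl)c(Cl)c4)c3)cc2-c2ccncc2)ccc1Cl`, is the reference point. In a functional assay on UO-31 cells (Homo sapiens) for inhibition, read by sulforhodamine B assay, with a stated time of 48 h (on this read-out lower numbers stand for stronger inhibition of growth and higher numbers for weaker inhibition of growth), compound 1 gives 4980 nM. Compound 3, `O=C(Nc1cccc(-n2cc(-c3ccncc3)c(-c3ccc(Cl)c(O)c3)n2)c1)Nc1cc(C(F)(F)F)cc(C(F)(F)F)c1`, gives 1900 nM in this assay, so compound 1 holds the higher of the two numbers that were read out, and the gap between them is beyond the scatter. Compound 2, `O=C(Nc1cccc(-n2cc(-c3ccncc3)c(-c3ccc(Cl)c(O)c3)n2)c1)Nc1ccc(Cl)c(Cl)c1`, sits at a limit of this assay, > 32500 nM, which is the limit described by the limit of > 32500 nM in this assay, at which 1 of the 3 values shown sits. For the measured compounds named here, the one measured step, an at least 6.5-fold higher number from compound 1 to compound 2 (0.81 log units; beyond the scatter), changes the oxygen on an aromatic ring and is therefore a change at a different place from the one followed here.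

Compound 4 is `COc1cc(-c2nn(-c3cccc(NC(=O)c4ccccc4)c3)cc2-c2ccncc2)ccc1Cl`. It differs from compound 1 by phenyl in place of (3,4-dichlorophenyl)amino on a carbonyl carbon. Going by the values given here, no measured step touches this end of the molecule, so nothing in the numbers above tells how large a step to expect, or in which direction. Taken as a guess rather than an inference from a measured step, compound 4 is expected to give a somewhat higher number, that is weaker growth inhibition, in this assay, a step of a 1.8-fold higher number from compound 1 to compound 4 (0.26 log units; within the scatter). The estimate for compound 4 in this assay is 9000 nM, with a range from 2500 nM to 32500 nM.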

Compound 4, concentration for total growth inhibition: > 100000 nM
Compound 4 gave a limit, no number; the forecaster's own chance of this, stated with the estimate: 25%; middle value at least 11-fold (1.04 log units) from the limit.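

Swapping the (3,4-dichlorophenyl)amino on the carbonyl carbon for phenyl gives, in this assay, an at least 20-fold higher number from compound 1 to compound 4 (1.30 log units; beyond the scatter) and is the first measured sign that this end of the molecule, and not only the oxygen on the aromatic ring, bears on growth inhibition. In this assay, on these data alone, compound 4 gives > 100000 nM and that is a limit and not a number, so the full size of this step stays unknown: the limit of > 100000 nM in this assay, at which 1 of the 4 values shown sits. The change removes the two chlorines and the nitrogen with its hydrogen-bond donor in one move, so this single step cannot tell which of these parts matters.

An unsubstituted phenylamino group on the same carbonyl carbon would keep the nitrogen without the chlorines, and a 3,4-dichlorophenyl group placed directly on that carbon would keep the chlorines without the nitrogen, and the compounds shown include neither. They also leave open how a simple chain such as methylamino or ethylamino would read in place of the ring at this position.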